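Methoxy for ethyl on the aryl amide of compound 3

The source may hold more compounds than are shown below. What is called first, only, known or untested is meant among the compounds shown, and "the series" means these compounds.

Three amides sharing one core have been measured in a functional assay on SK-BR-3 cells (Homo sapiens) for antiproliferative activity, read by MTT assay, with a stated time of 72 h; on this read-out higher numbers stand for weaker inhibition and lower numbers for stronger inhibition. Compound 1 `CCN1CCN(c2cc(C)c3cc(NC(=O)c4cccc(Cl)c4)ccc3n2)CC1` gives 17800 nM, compound 2 `CCc1ccc(C(=O)Nc2ccc3nc(N4CCN(CC)CC4)cc(C)c3c2)cc1` gives 9850 nM, and compound 3 `CCc1ccccc1C(=O)Nc1ccc2nc(N3CCN(CC)CC3)cc(C)c2c1` gives 23900 nM. Compound 3 stands at the highest number of the three: its nearest neighbour is compound 1, with a 1.3-fold higher number from compound 1 to compound 3 (0.13 log units; within the scatter), and its furthest is compound 2, with a 2.4-fold higher number from compound 2 to compound 3 (0.38 log units; beyond the scatter). Between compound 1 and compound 2 the step was a 1.8-fold lower number from compound 1 to compound 2 (0.26 log units; within the scatter).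

Compound 4 `CCN1CCN(c2cc(C)c3cc(NC(=O)c4ccc(OC)cc4)ccc3n2)CC1` differs from compound 3 in one place: 4-methoxyphenyl in place of 2-ethylphenyl on a carbonyl carbon. The step from compound 2 to compound 3 is the one that bears on this change, as it also exchanged a 2-ethylphenyl for a 4-substituted phenyl on the same carbonyl carbon, and that step was modest but beyond the scatter. The step from compound 1 to compound 2 adds that a 4-ethylphenyl sat at the lowest number seen. Going by the values given here, no measured step isolates methoxy against ethyl, so the estimate leans on these two steps alone.

Compound 4 is therefore expected to move in this assay by a 2.2-fold lower number from compound 3 to compound 4 (0.34 log units; beyond the scatter), toward a lower number. The value of compound 4 is estimated at 11000 nM, within a range from 4000 nM to 30000 nM.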

Compound 4, half-maximal inhibitory concentration: 9000 nM
For compound 4 the middle estimate is 1.2-fold (0.09 log units) above the measured one, within the range that was stated.
By their numbers in this assay, from the lowest: compounds 4, 2, 1 and 3 (each within the scatter of the next, the first and the last beyond it).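

In this assay, going by these compounds alone, 4-methoxyphenyl in place of 2-ethylphenyl on the carbonyl carbon gives a 2.7-fold lower number from compound 3 to compound 4 (0.42 log units; beyond the scatter), a second step beyond the scatter away from compound 3 after the one to compound 2, while methoxy in place of ethyl on an aromatic carbon gives a 1.1-fold lower number from compound 2 to compound 4 (0.04 log units; within the scatter), so the two groups cannot be told apart here. Compound 1 does not fit a simple split between 2-ethylphenyl and the other groups, since 4-methoxyphenyl in place of 3-chlorophenyl gives a 2.0-fold lower number from compound 1 to compound 4 (0.30 log units; within the scatter), also within the scatter, and compound 1 lies within the scatter of compound 3 as well. Nothing shown here accounts for these differences.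

The compounds shown leave open how 2-methoxyphenyl on the same carbonyl carbon would compare with 2-ethylphenyl and 4-methoxyphenyl. They also leave open whether a dimethylamino group, a carboxylic acid or a butyl chain in place of methoxy would shift the number in this assay.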